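Dropping one chloro from a dichlorophenyl sulfone

A few compounds are considered here, and "the series" means these few. Any claim that something is new, unique, unknown or untested is made for them only; others in the source may bear on it.

Compound 1 `O=S(=O)(/C=C/c1ccc(F)cc1)Cc1ccc(Nc2ncnc3ccccc23)cc1`: 10 nM
Compound 2 `O=S(=O)(/C=C/c1ccc(Cl)c(Cl)c1)Cc1ccc(Nc2ncnc3ccccc23)cc1`: 28000 nM

In a functional assay on ACHN cells (Homo sapiens) (a higher number here means a weaker inhibitor of growth, a lower number a stronger inhibitor of growth), compound 2 has the higher of the two numbers, 28000 nM, so it is the weaker inhibitor of the pair. Compound 3 `O=S(=O)(/C=C/c1ccc(Cl)cc1)Cc1ccc(Nc2ncnc3ccccc23)cc1` differs from compound 2 at one place: hydrogen in place of chloro on an aromatic carbon. In other words, hydrogen replaces chloro on an aromatic carbon, turning 3,4-dichlorophenyl into 4-chlorophenyl.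

Going by the values given here, only one measured step bears on this change: a 2800-fold higher number from compound 1 to compound 2 (3.45 log units; beyond the scatter). It is large and well beyond the scatter, and it places 3,4-dichlorophenyl where compound 1 has 4-fluorophenyl. Among the compounds with values here, that step swaps the halogen at one spot and adds a chloro at another, and no measurement yet separates the two parts. Compound 3 shares its single-halogen pattern with compound 1, so a large drop in the number is expected, though perhaps not all the way to the value of compound 1. The expected change is a 280-fold lower number from compound 2 to compound 3 (2.45 log units; beyond the scatter). For compound 3, the estimated value is 100 nM, with an expected range of 10 nM to 3000 nM.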

Compound 3, concentration for 50% growth inhibition: > 100000 nM
Compound 3 gave a limit, no number; the forecaster's own chance of this, stated with the estimate: 5%; at least 1000-fold (3.00 log units) between middle value and limit.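

In this assay compound 3 gives a limit rather than a number: the limit of > 100000 nM in this assay, at which 1 of the 3 values shown sits.

Removing one chloro does not recover growth inhibition. Instead the result is an at least 3.5-fold higher number from compound 2 to compound 3 (0.55 log units; beyond the scatter), so the weak result of compound 2 does not depend on the extra chloro of its 3,4-dichlorophenyl group. Going by these compounds alone, the single exchange of fluoro for chloro at the same place on the aromatic ring gives an at least 10000-fold higher number from compound 1 to compound 3 (4.00 log units; beyond the scatter), which separates the two parts of the earlier step: the large loss already appears with this halogen exchange alone, with no second chloro present.

Only fluoro and chloro appear at this place in the compounds shown, so it remains open whether hydrogen, a methyl or a methoxy group there would behave like the fluoro of compound 1 or like the chloro of compound 3. Going by these compounds, since the result for compound 3 is a limit, the true size of its gap to the other two compounds also remains open, as does the behaviour of a 3-chlorophenyl group, which would test the other chloro on its own.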